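The compounds below may be only part of what the source reports. "The series", "measured", "known", "first", "only" and "open" are said of these compounds alone.

Measured compounds in an assay on isolated protein (Cricetulus griseus) for binding affinity to Alpha-1B adrenergic receptor (Mesocricetus auratus), read by radioligand binding; a lower number here means a stronger inhibitor, a higher number a weaker inhibitor:
compound 1 `CCCS(=O)(=O)Nc1cccc2c1CCCC2c1c[nH]cn1` gives < 10000 nM, a limit of the assay.
compound 2 `CCS(=O)(=O)Nc1cc(F)cc2c1CCCC2c1c[nH]cn1` gives < 10000 nM, again a limit.
compound 3 `CCS(=O)(=O)Nc1cccc(-c2c[nH]cn2)c1` gives < 10000 nM, likewise a limit and not a number.

Compound 3 therefore stands only at the limit (the limit of < 10000 nM in this assay, at which 3 of the 3 values shown sit), with no measured number to place it more closely. Among the measured compounds shown here, no step between two measured compounds is available here, so no direction or size of change beyond the usual scatter can be read from these three.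

Compound 4 `CCS(=O)(=O)Nc1cccc(Sc2c[nH]cn2)c1` differs from compound 3 by (1H-imidazol-4-yl)sulfanyl in place of 1H-imidazol-4-yl on an aromatic carbon. With nothing but limits behind it, compound 4 is expected to land near 2000 nM in this assay, within a range from 200 nM to 10000 nM. That expectation corresponds to an estimated step that the limit leaves unreadable from compound 3 to compound 4.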

Compound 4, inhibition constant: < 10000 nM
Compound 4: only a limit was reported (the forecaster's own chance of this, stated with the estimate: 70%); the middle value does not contradict the limit.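

Among the compounds shown here, compound 4, like compound 3, gives only a limit, so no step between them can be read: the limit of < 10000 nM in this assay, at which 4 of the 4 values shown sit. The compounds shown leave open how strongly each one actually binds in this assay and whether the sulfanyl link changes that.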